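The source may report more compounds than this note shows. Statements on the series, on what has been measured and on what is new or still open speak of the compounds shown alone.

Measured so far in a functional assay on M14 cells (Homo sapiens) for cytotoxicity, read by sulforhodamine B assay, with a stated time of 48 h; a lower number here means that less compound is tolerated, a higher number that more compound is tolerated:
compound 1 `ClCc1ccc(Cn2cnc3nc(Cl)nc(Cl)c32)cc1`: 6910 nM
compound 2 `ClCc1ccccc1Cn1cnc2ncnc(Cl)c21`: 27500 nM
compound 3 `ClCc1ccccc1Cn1cnc2nc(Cl)nc(Cl)c21`: 6450 nM

Compound 1 and compound 3 are built from the same atoms joined differently; the difference between the two cores is not broken down here. In this assay compound 1 and compound 3 give numbers that lie within the scatter of each other, while compound 2 stands apart from both.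

Among the compounds with values here, the single counted step among the measured compounds runs from compound 3 to compound 2, (hydrogen in place of chloro on an aromatic carbon), and it gives a 4.3-fold higher number from compound 3 to compound 2 (0.63 log units; beyond the scatter).

Compound 4 `ClCc1ccc(Cn2cnc3ncnc(Cl)c32)cc1` has not yet been measured. It differs from compound 1 by hydrogen in place of chloro on an aromatic carbon. The place of the change is described in the same words as for the step from compound 3 to compound 2, so this is the same change made on the other core.

Because the earlier step gave a 4.3-fold higher number from compound 3 to compound 2 (0.63 log units; beyond the scatter), a step of similar size is expected here, namely a 4.1-fold higher number from compound 1 to compound 4 (0.61 log units; beyond the scatter). For compound 4 in this assay the expected value is 28000 nM, with a likely range from 12000 nM to 65000 nM.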

Compound 4, concentration lethal to 50% of the cells: 37200 nM
Compound 4: middle estimate off by 1.3-fold (0.12 log units), on the low side; the measured number falls inside the stated range.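

In this assay, putting hydrogen in place of chloro on the aromatic carbon between two ring nitrogen atoms gives a 5.4-fold higher number from compound 1 to compound 4 (0.73 log units; beyond the scatter). The change therefore carries over from one core to the other with a similar size, and the two steps cannot be told apart in this assay: the same change on two cores in this assay, a 4.3-fold higher number (0.63 log units; beyond the scatter) from compound 3 to compound 2 and a 5.4-fold higher number (0.73 log units; beyond the scatter) from compound 1 to compound 4, 1.3-fold (0.10 log units) apart, within the scatter of two such steps. This rests on just two pairs of compounds in a single cell line, so it shows neither that the step would keep its size on a core of any other kind nor that it would do so on other cells, and it gives no reason why the number rises.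

At the changed place the compounds shown carry only chloro or hydrogen, so the effect of an amine or a methoxy group there remains open. As far as these compounds go, all four compounds also keep the chloromethyl group and the other chloro group, so what a hydroxymethyl group or an amine would do in place of either is equally open.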